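The source may report more compounds than this note shows. Statements on the series, on what has been measured and on what is new or still open speak of the compounds shown alone.

Values in an ADME assay on HepG2 2.2.15 cells (Homo sapiens) for cytotoxicity; on this read-out higher numbers stand for lower toxicity in this test and lower numbers for higher toxicity in this test:
- compound 1 `CC(=O)NCC(=O)OCCc1c(-c2ccccc2Cl)c2cc(Cl)ccc2[nH]c1=O`: 110000 nM
- compound 2 `O=C(/C=C/c1cccc(F)c1)OCCc1c(-c2ccccc2Cl)c2cc(Cl)ccc2[nH]c1=O`: > 1600000 nM (a limit of the assay)

Compound 2 stands at a limit and not at a number: the limit of > 1600000 nM in this assay, at which 1 of the 2 values shown sits. Compound 3 `COc1ccccc1/C=C/C(=O)OCCc1c(-c2ccccc2Cl)c2cc(Cl)ccc2[nH]c1=O` is defined by the change (2-methoxyphenyl in place of 3-fluorophenyl on a double-bonded chain carbon bound to a double-bonded chain carbon). Within the data shown here, the one measured step bearing on it is an at least 14-fold higher number from compound 1 to compound 2 (1.16 log units; beyond the scatter), a large step that brought in 2-(3-fluorophenyl)ethenyl. Compound 3 keeps that position as 2-(2-methoxyphenyl)ethenyl, so no step beyond the scatter is expected in this assay. The estimated step is an at least 1.6-fold lower number from compound 2 to compound 3 (0.20 log units; that floor lies within the scatter). For compound 3 the expected value is 1000000 nM, with an estimated range of 250000 nM to 2000000 nM.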

Compound 3, half-maximal cytotoxic concentration: 770000 nM
The estimate for compound 3 lay 1.3-fold (0.11 log units) above the measured number; the range from low to high includes it.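

In this assay, the aryl group on the ethenyl chain matters: 2-methoxyphenyl in place of 3-fluorophenyl gives an at least 2.0-fold lower number from compound 2 to compound 3 (0.31 log units; beyond the scatter). Compound 2 stands at a limit of the assay, so the true size of that step stays unknown: the limit of > 1600000 nM in this assay, at which 1 of the 3 values shown sits.

The higher number over the acetamidomethyl ester is not confined to 3-fluorophenyl, as 2-(2-methoxyphenyl)ethenyl in place of acetamidomethyl gives a 7.0-fold higher number from compound 1 to compound 3 (0.85 log units; beyond the scatter).

Still open, as far as these compounds go, is whether the drop follows the entering methoxy group or the departing fluorine, since both change together. Also open, from the compounds shown here alone, is how an amine or a carboxylic acid at this place would read.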